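The source may hold more compounds than are shown below. What is called first, only, known or untested is meant among the compounds shown, and "the series" means these compounds.

In a functional assay on BXPC-3 cells (Homo sapiens) for inhibition, read by MTT assay, with a stated time of 72 h (on this read-out higher numbers stand for weaker inhibition of growth and lower numbers for stronger inhibition of growth), compound 2 `O=S(=O)(NCCCNCc1ccccc1Cl)c1cc(C(F)(F)F)cc(C(F)(F)F)c1` gives 11000 nM. Compound 1 `CC(C)(C)c1ccc(CNCCNS(=O)(=O)c2cc(C(F)(F)F)cc(C(F)(F)F)c2)cc1` gives 8800 nM in the same assay, and the two numbers lie within the scatter of each other, so compound 2 sits at the higher end of the two values without being set apart from compound 1. Compound 3 `COc1ccc(CNCCCNS(=O)(=O)c2cc(C(F)(F)F)cc(C(F)(F)F)c2)cc1` differs from compound 2 in one place: 4-methoxyphenyl in place of 2-chlorophenyl on a saturated chain carbon bound to an amine nitrogen. Among the compounds with values here, no measured pair shows this change, so the step from compound 2 to compound 3 is expected to stay within the scatter, a 1.1-fold higher number from compound 2 to compound 3 (0.04 log units; within the scatter). Compound 3 is therefore estimated at 12000 nM, with a range from 5000 nM to 30000 nM.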

Compound 3, concentration for 50% growth inhibition: 1300 nM
Estimate against measurement, compound 3: 9.2-fold (0.97 log units) above; measured number below the stated range.
By their numbers in this assay, from the lowest: compound 3; then compounds 1 and 2 (each within the scatter of the next).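

In this assay, within the data shown here, the group on the saturated chain carbon bound to an amine nitrogen clearly affects the read-out: 4-methoxyphenyl in place of 2-chlorophenyl gives an 8.5-fold lower number from compound 2 to compound 3 (0.93 log units; beyond the scatter), a step the earlier compounds did not show, as their two values lay within the scatter and they differ in more than one place. Nothing given here accounts for this step. The compounds shown leave open whether the methoxy group itself or the loss of the chlorine matters, and whether an ethoxy or a dimethylamino group in place of the methoxy would hold the lower number.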